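Cyclobutyl for tert-butyl on a sulfonamide in a pancreatic cell assay

The source may report more compounds than this note shows. Statements on the series, on what has been measured and on what is new or still open speak of the compounds shown alone.

Compound 1 `CC(C)c1noc(N2CCN(C(=O)[C@@H]3CCCN(S(=O)(=O)c4ccc(S(=O)(=O)NC(C)(C)C)cc4)C3)CC2)n1` is the stronger of two compounds tested in a functional assay on BXPC-3 cells (Homo sapiens) for inhibition, read by MTT assay, with a stated time of 7 days; a lower number here means a stronger inhibitor, a higher number a weaker inhibitor: compound 1 gives 2600 nM, while compound 2 `CCOC(=O)C1CN(S(=O)(=O)c2ccc(S(=O)(=O)N(CC)CC)cc2)C1` gives 12700 nM, a gap beyond the scatter. Compound 3 `CC(C)c1noc(N2CCN(C(=O)[C@@H]3CCCN(S(=O)(=O)c4ccc(S(=O)(=O)NC5CCC5)cc4)C3)CC2)n1` differs from compound 1 in one place: cyclobutyl in place of tert-butyl on a sulfonamide nitrogen. Within the data shown here, no measured pair here shows what such a swap does, so the step is expected to be small, likely none beyond the scatter, in either direction. Compound 3 is therefore estimated at 2600 nM, within 1200 nM to 6000 nM, a step from compound 1 to compound 3 of no change at the digits printed from compound 1 to compound 3 (within the scatter).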

Compound 3, half-maximal inhibitory concentration: 3300 nM
Estimate against measurement, compound 3: 1.3-fold (0.10 log units) below; the range from low to high includes it.
By their numbers in this assay, from the lowest: compounds 1 and 3 (each within the scatter of the next); then compound 2.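

Among these compounds, this is the first reading at the sulfonamide nitrogen: cyclobutyl in place of tert-butyl gives a 1.3-fold higher number from compound 1 to compound 3 (0.10 log units; within the scatter) in this assay and so leaves the number within the scatter. At this position, a four-membered ring of carbon only can take the place of tert-butyl, with the same count of heavy atoms, without a step beyond the scatter. Nothing available explains why the two groups read alike. On these data alone, what an amine, a carboxylic acid or a longer chain would do on this nitrogen stays open. As far as these compounds go, whether the same swap would read alike on another core also stays open.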